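Swapping a Propargyl Ester for a Propyl Ester

This account rests on a few compounds, and the source may have more. Where it says the series, first, only, none or still open, it means among the compounds named here.

Compound 1, `C#CCOC(=O)C[C@@H]1C(C(=O)OC)=CO[C@@H](O[C@@H]2O[C@H](COC(C)=O)[C@@H](OC(C)=O)[C@H](OC(C)=O)[C@H]2OC(C)=O)/C1=C/C`: > 15000 nM in a functional assay on SK-BR-3 cells (Homo sapiens) for antiproliferative activity, read by MTT assay, with a stated time of 72 h (a lower number here means a stronger inhibitor, a higher number a weaker inhibitor), a limit of the assay rather than a number.
Compound 2, `C=C(C)CCOC(=O)C[C@@H]1C(C(=O)OC)=CO[C@@H](O[C@@H]2O[C@H](CO)[C@@H](O)[C@H](O)[C@H]2O)/C1=C/C`: > 15000 nM in this assay, likewise only a limit.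
Compound 3, `C/C=C1/[C@H](O[C@@H]2O[C@H](CO)[C@@H](O)[C@H](O)[C@H]2O)OC=C(C(=O)OC)[C@H]1CC(=O)OCCc1ccc(O)c(O)c1`: 160000 nM in this assay.

Compound 1 thus stands only at a limit; among the three values shown, (the limit of > 15000 nM in this assay, at which 2 of the 3 values shown sit). Within the data shown here, compound 3 gives the single real number. Among the measured compounds shown here, the one measured step between compounds differing in a single place, a step that the limit leaves unreadable from compound 2 to compound 3, cannot be read because compound 2 sits at the limit. Compound 4, `C/C=C1/[C@H](O[C@@H]2O[C@H](COC(C)=O)[C@@H](OC(C)=O)[C@H](OC(C)=O)[C@H]2OC(C)=O)OC=C(C(=O)OC)[C@H]1CC(=O)OCCC`, differs from compound 1 by ethyl in place of ethynyl on a saturated chain carbon bound to an oxygen next to a carbonyl group. For the measured compounds named here, no measured step touches this change, so no direction can be drawn from the data. Compound 4 is therefore expected to show a step that the limit leaves unreadable from compound 1 to compound 4, within the scatter, and is estimated at 40000 nM, with a range from 15000 nM to 200000 nM, quite possibly reported again only as a limit.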

Compound 4, half-maximal inhibitory concentration: 6600 nM
The estimate for compound 4 lay 6.1-fold (0.78 log units) above the measured number, and the stated range ends above it.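

In this assay, ethyl in place of ethynyl on a saturated chain carbon bound to an oxygen next to a carbonyl group gives an at least 2.2-fold lower number from compound 1 to compound 4 (0.35 log units; beyond the scatter). Among these compounds, this is the first readable step at this position, and it shows that removing the triple bond, with the heavy-atom count of the group unchanged, is enough to bring a real number into view. The full size of the step stays unknown, since compound 1 is only a limit: the limit of > 15000 nM in this assay, at which 2 of the 4 values shown sit.

As far as these compounds go, whether an amine or a longer chain in place of ethyl would lower the number further remains open.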